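The source may report more compounds than this note shows. Statements on the series, on what has been measured and on what is new or still open speak of the compounds shown alone.

Measured so far in a functional assay on HL-60 cells (Homo sapiens) for antiproliferative activity, read by MTT assay, with a stated time of 48 h; a higher number here means a weaker inhibitor, a lower number a stronger inhibitor:
compound 1 `CC(C)=CCC[C@]1(C)/C=C/[C@@H](OC(=O)C=C(C)C)[C@](C)(O)/C=C/C(=O)/C(CN2CCCC2)=C\C1` gives 160 nM;
compound 2 `CC(C)=CCC[C@](C)(/C=C/[C@@H](OC(=O)C=C(C)C)[C@](C)(O)/C=C/C(=O)/C=C/N(C)C)CC=O` gives 4690 nM.

Of these two values, compound 1 has the lower number and compound 2 sits far higher, a gap beyond the usual scatter of this measurement. Compound 3 `CC(C)=CCC[C@]1(C)/C=C/[C@@H](OC(=O)C=C(C)C)[C@](C)(O)/C=C/C(=O)/C(C(=O)N(C)C)=C\C1` has not yet been measured. It differs from compound 1 in one place: dimethylcarbamoyl in place of (pyrrolidin-1-yl)methyl on a double-bonded ring carbon. Among the compounds with values here, no step between measured compounds resembles this change, so its size is uncertain; a moderate weakening in this assay is expected, of about a 3.1-fold higher number from compound 1 to compound 3 (0.49 log units; beyond the scatter). Compound 3 is therefore estimated at 500 nM, with a likely range from 120 nM to 2500 nM.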

Compound 3, half-maximal inhibitory concentration: 3340 nM
For compound 3 the middle estimate is 6.7-fold (0.82 log units) below the measured one; the whole stated range lies below it.
By their numbers in this assay, from the lowest: compound 1; then compounds 3 and 2 (each within the scatter of the next).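

In this assay putting dimethylcarbamoyl in place of (pyrrolidin-1-yl)methyl on this double-bonded ring carbon brings a 21-fold higher number from compound 1 to compound 3 (1.32 log units; beyond the scatter) and shows that activity depends strongly on the group held here. Both groups carry no net charge and have the same hydrogen-bond acceptor count, so those counts do not separate them. No measurement available here explains the loss.

Two things changed at once, the ring and the carbonyl. As far as these compounds go, a (dimethylamino)methyl group on the same carbon would show which of them matters, and how a simple methyl would fare remains open.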